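Side-chain changes at the ether oxygen of compound 2

The source may hold more compounds than are shown below. What is called first, only, known or untested is meant among the compounds shown, and "the series" means these compounds.

Three compounds share one core and differ only in the group on the oxygen on a saturated carbon; all were measured in a functional assay on DU-145 cells (Homo sapiens) for cytotoxicity, read by MTT assay; on this read-out higher numbers stand for weaker inhibition and lower numbers for stronger inhibition.

compound 1 `CC(=O)OCCO[C@H](CC=C(C)C)C1=CC(=O)c2c(O)ccc(O)c2C1=O`: 15500 nM
compound 2 `CC(C)=CC[C@@H](OC[C@@H](C)O)C1=CC(=O)c2c(O)ccc(O)c2C1=O`: 14300 nM
compound 3 `CC(C)=CC[C@@H](OC(=O)C1CCOC1)C1=CC(=O)c2c(O)ccc(O)c2C1=O`: 47500 nM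

Compound 2 gives the lowest of the three numbers, yet compound 1 lies within the scatter of it, as a 1.1-fold lower number from compound 1 to compound 2 (0.03 log units; within the scatter) shows; only compound 3 stands apart, with a 3.3-fold higher number from compound 2 to compound 3 (0.52 log units; beyond the scatter). Compound 4 `COCCO[C@H](CC=C(C)C)C1=CC(=O)c2c(O)ccc(O)c2C1=O` is not yet measured. Relative to compound 2 it carries methoxymethyl in place of 1-hydroxyethyl on a saturated chain carbon bound to an oxygen on a saturated carbon. Among the measured compounds shown here, the one measured step that bears on this, a 1.1-fold lower number from compound 1 to compound 2 (0.03 log units; within the scatter), reworked the outer part of the same chain and stayed within the scatter, so no step beyond the scatter is expected in this assay. The estimate for compound 4 is 15000 nM (range 7000 nM to 32000 nM), which is expected to mean a 1.0-fold higher number from compound 2 to compound 4 (0.02 log units; within the scatter).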

Compound 4, half-maximal inhibitory concentration: 43200 nM
Estimate against measurement, compound 4: 2.9-fold (0.46 log units) below, outside the stated range (above it).
By their numbers in this assay, from the lowest: compounds 2 and 1 (each within the scatter of the next); then compounds 4 and 3 (each within the scatter of the next).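

In this assay the outer part of this chain turns out to matter, since 2-methoxyethyl in place of 2-hydroxypropyl gives a 3.0-fold higher number from compound 2 to compound 4 (0.48 log units; beyond the scatter) and methyl in place of acetyl gives a 2.8-fold higher number from compound 1 to compound 4 (0.45 log units; beyond the scatter) even though the earlier change in this chain stayed within the scatter. The 2-methoxyethyl chain cannot be told apart from (oxolan-3-yl)carbonyl, with a 1.1-fold lower number from compound 3 to compound 4 (0.04 log units; within the scatter) on that comparison. Nothing measured here explains these steps. Still open, as far as these compounds go, is how an amine or a carboxylic acid at the end of this chain would read, and whether a longer chain would keep the lower numbers.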